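This account rests on a few compounds, and the source may have more. Where it says the series, first, only, none or still open, it means among the compounds named here.

Compound 1 `C=CCOc1nc(N)nc2c1ncn2/C=C1/CC1(CO)CO`: > 20000 nM
Compound 2 `Nc1nc(NCc2ccccc2)c2ncn(/C=C3/CC3(CO)CO)c2n1`: 19900 nM

In an ADME assay on BCBL1 cells (Homo sapiens) for cytotoxicity, with a stated time of 7 days (a higher number here means that more compound is tolerated, a lower number that less compound is tolerated), compound 1 reaches only a limit of the assay, > 20000 nM, so no exact number stands for it. Compound 2 gives 19900 nM in this assay. The step of a number no higher from compound 1 to compound 2 (the limit leaves the size open) therefore cannot be sized; as the limit of > 20000 nM in this assay, at which 1 of the 2 values shown sits, shows, one of the two values sits at that limit.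

Compound 3 `CCCNc1nc(N)nc2c1ncn2/C=C1/CC1(CO)CO` is not yet measured. It differs from compound 1 by propylamino in place of allyloxy on an aromatic carbon. Among the compounds with values here, the only measured step, which replaced the same allyloxy group with benzylamino, left compound 2 near the limit, and an exchange of allyloxy for propylamino at the same place is expected to behave alike. The step of a number no higher from compound 1 to compound 3 (the limit leaves the size open) is therefore expected to stay within the scatter. Compound 3 is estimated at 20000 nM, between 9000 nM and 45000 nM, most likely again reported as a limit.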

Compound 3, half-maximal cytotoxic concentration: > 20000 nM
Compound 3 was reported as a limit; the forecaster's own chance of this, stated with the estimate: 70%; the middle value lies on the limit itself.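

In this assay compound 3 gives > 20000 nM, which is a limit of the assay and not an exact number. Propylamino, joined to the aromatic carbon through nitrogen and bringing a hydrogen-bond donor, therefore also ends in a limit, as the oxygen-linked allyloxy group of compound 1 does. The data give only a number no lower from compound 2 to compound 3 (the limit leaves the size open). The size of the steps from compound 1 and compound 2 to compound 3 cannot be read, and this assay separates these compounds poorly, since the values gather at one end of its range: the limit of > 20000 nM in this assay, at which 2 of the 3 values shown sit.

From the compounds shown here alone, it remains open whether an octylamino chain or a carboxylic acid at this place would give an exact number in this assay. Any real difference between allyloxy and propylamino also stays hidden behind the limit.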